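Aryl exchange on the shared core: estimating compound 4

The source may report more compounds than this note shows. Statements on the series, on what has been measured and on what is new or still open speak of the compounds shown alone.

Measured compounds:
compound 1, `O=C(O)Cc1sc(C(c2ccc(F)cc2)c2ccc(F)cc2)nc1-c1ccnc(F)c1`: 0.48 nM
compound 2, `O=C(O)Cc1sc(C(c2ccccc2)c2ccccc2)nc1-c1ccc(C(F)(F)F)cc1`: 1100 nM
compound 3, `COc1ccc(OC)c(-c2nc(C(c3ccccc3)c3ccccc3)sc2CC(=O)O)c1`: a limit, > 105 nM

All three were tested in an in vitro assay on HEK385-7 cells for displacement of a labelled ligand from prostaglandin D2 receptor 2 (Homo sapiens); on this read-out higher numbers stand for weaker inhibition and lower numbers for stronger inhibition. Compound 1 gives the lowest of the two numbers; the nearest, compound 2, sits at a higher number beyond the scatter. For compound 3 only a limit is reported, not a number. The step that the limit leaves unreadable from compound 2 to compound 3 cannot be sized because the limit of > 105 nM in this assay, at which 1 of the 3 values shown sits, hides where compound 3 lies.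

Compound 4, `CS(=O)(=O)Nc1cccc(-c2nc(C(c3ccc(F)cc3)c3ccc(F)cc3)sc2CC(=O)O)c1`, is not yet measured. It differs from compound 1 in one place:

3-(methanesulfonamido)phenyl in place of 2-fluoropyridin-4-yl on an aromatic carbon

For the measured compounds named here, no measured step follows this kind of change. The only step shown exchanges the aryl group at the same place, but it is unreadable, and compound 1 and compound 2 differ in more than one place, so their gap cannot be assigned to that position alone. What the two numbers show is that the aryl at this place can shift the read-out by a large amount. For compound 4 a moderate upward step is expected, a 10-fold higher number from compound 1 to compound 4 (1.02 log units; beyond the scatter), beyond the scatter but well short of the gap between compound 1 and compound 2. Compound 4 is estimated at 5 nM, with a range from 0.5 nM to 50 nM.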

Compound 4, half-maximal inhibitory concentration: 40 nM
Beside the measured number, compound 4's estimate is 8.0-fold (0.90 log units) below it, and the stated range covers the measured number.
By their numbers in this assay, from the lowest: compound 1; then compound 4; then compound 2.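

In this assay, replacing 2-fluoropyridin-4-yl with 3-(methanesulfonamido)phenyl, on the aromatic carbon next to the ring nitrogen, gives an 83-fold higher number from compound 1 to compound 4 (1.92 log units; beyond the scatter). For the compounds shown here, this is the first readable step at this position with everything else in the core of compound 1 held fixed, so the read-out's sensitivity to the aryl group here no longer rests on a gap between compounds that differ in more than one place. The step still covers the whole exchange, in which the ring nitrogen and the fluorine leave and the methanesulfonamido group enters, and as a single pair it sets no trend for other aryl groups.

Compound 3 has only a limit, not a number, so the aryl exchange leading to it from compound 2 cannot be read: the limit of > 105 nM in this assay, at which 1 of the 4 values shown sits.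

Going by these compounds, it also remains open which part of the exchange carries the step, and how the read-out would respond on the shared core to an unsubstituted phenyl, which would separate the loss of the ring nitrogen from the entry of the sulfonamide, or to a 3-aminophenyl group, which would keep the nitrogen on the ring but lack the sulfonyl.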